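From a dipropylamino limit to a secondary amine

The source may report more compounds than this note shows. Statements on the series, on what has been measured and on what is new or still open speak of the compounds shown alone.

In a functional assay on SK-BR-3 cells (Homo sapiens) for antiproliferative activity (on this read-out lower numbers stand for stronger inhibition and higher numbers for weaker inhibition), compound 3 `CCCN(CCC)CCCOc1ccc2cc(NC(=O)c3ccc(O)c(CC=C(C)C)c3)c(=O)oc2c1C` gives > 50000 nM, which is a limit and not a number. Compound 4 `CC(C)=CCc1cc(C(=O)Nc2cc3ccc(OCCCNCC(C)C)c(C)c3oc2=O)ccc1O` carries isobutylamino in place of dipropylamino on a saturated chain carbon, three bonds along the chain from an oxygen on an aromatic ring. Its nearest measured relative is compound 2 `CCCNCCCOc1ccc2cc(NC(=O)c3ccc(O)c(CC=C(C)C)c3)c(=O)oc2c1C`, which gives 990 nM. The bearing step is large, an at least 50-fold higher number from compound 2 to compound 3 (1.70 log units; beyond the scatter), and it adds only a propyl on the amine nitrogen. Compound 1 `CC(C)=CCc1cc(C(=O)Nc2cc3ccc(OCC4CCN(C)C4)c(C)c3oc2=O)ccc1O` gives 920 nM, although its nitrogen also has no hydrogen, so it goes against any simple pattern: an at least 54-fold higher number from compound 1 to compound 3 (1.73 log units; beyond the scatter). A large fall is therefore expected, with the estimated step of an at least 41-fold lower number from compound 3 to compound 4 (1.61 log units; beyond the scatter). For compound 4 the estimate is 1200 nM, with an expected range of 400 nM to 5000 nM.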

Compound 4, half-maximal inhibitory concentration: 1030 nM
The estimate for compound 4 lay 1.2-fold (0.07 log units) above the measured number, within the range that was stated.
By their numbers in this assay, from the lowest: compounds 1, 2 and 4 (each within the scatter of the next). At a limit, above all of these: compound 3.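

Compound 3 stands at a limit and not at a number. In this assay, isobutylamino in place of dipropylamino gives a measurable value (an at least 48-fold lower number from compound 3 to compound 4 (1.68 log units; beyond the scatter)), and the branched chain matches the straight propyl of compound 2 (a 1.0-fold higher number from compound 2 to compound 4 (0.02 log units; within the scatter)) and the ring of compound 1 (a 1.1-fold higher number from compound 1 to compound 4 (0.05 log units; within the scatter)), both within the scatter. Among the open-chain amines, the two that keep the nitrogen hydrogen give numbers, although compound 1, with no such hydrogen, goes against any wider rule. Open, as far as these compounds go, is how dimethylamino or a primary amine would compare here, and whether the lost hydrogen or the two propyl groups set compound 3 apart.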